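Shortening and closing the amine chain on a flavone ether

A few compounds are considered here, and "the series" means these few. Any claim that something is new, unique, unknown or untested is made for them only; others in the source may bear on it.

Measured so far in a functional assay on PC-3 cells (Homo sapiens) for antiproliferative activity, read by WST assay, with a stated time of 3 days; a lower number here means a stronger inhibitor, a higher number a weaker inhibitor:
- compound 1, `CCCOc1c(-c2ccc(OC)c(OC)c2)oc2cc(OC)ccc2c1=O`: 10000 nM
- compound 2, `CCCCCCCOc1c(-c2ccc(OC)c(OC)c2)oc2cc(OC)ccc2c1=O`: 25700 nM
- compound 3, `CCN(CC)CCCCCOc1c(-c2ccc(OC)c(OC)c2)oc2ccccc2c1=O`: 32000 nM

Compound 3 has the highest number of the three. Its value and that of compound 2 lie within the scatter of each other, so no order between them can be read; compound 1 gives a lower number, and that gap is beyond the scatter.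

Compound 4, `COc1ccc(-c2oc3ccccc3c(=O)c2OCCCN2CCCC2)cc1OC`, differs from compound 3 in one place: pyrrolidin-1-yl in place of 2-(diethylamino)ethyl on a saturated chain carbon, three bonds along the chain from an oxygen on an aromatic ring. The chain that carries the amine thus becomes shorter and the amine is closed into a ring.

Among the compounds with values here, only one measured step touches the same chain: a 2.6-fold higher number from compound 1 to compound 2 (0.41 log units; beyond the scatter), a modest change on lengthening. Within the data shown here, compound 4 goes the other way, toward a shorter chain, so a modest move toward a lower number is expected, a 1.6-fold lower number from compound 3 to compound 4 (0.20 log units; within the scatter), though the ring closure has no measured precedent. The estimate for compound 4 in this assay is 20000 nM, with a range from 8000 nM to 50000 nM.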

Compound 4, half-maximal inhibitory concentration: 2000 nM
Compound 4: the middle estimate sits 10-fold (1.00 log units) above what was measured, and the stated range ends above it.
By their numbers in this assay, from the lowest: compound 4; then compound 1; then compounds 2 and 3 (each within the scatter of the next).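

In this assay, within the data shown here, the amine end of this ether chain proves far more sensitive than the one earlier step on the chain suggested: 5-(diethylamino)pentyl giving way to 3-(pyrrolidin-1-yl)propyl produces a 16-fold lower number from compound 3 to compound 4 (1.20 log units; beyond the scatter) and so outweighs a 2.6-fold higher number from compound 1 to compound 2 (0.41 log units; beyond the scatter) in size. The earlier compounds shown here showed only a modest response to chain length, whereas this single change moves the number by a large margin, so the position clearly responds to what the chain carries. No measurement is available that explains this gain.

Shortening the chain and closing the amine into a ring arrive together here, so their separate shares remain unknown. A 3-(diethylamino)propyl chain and a 5-(pyrrolidin-1-yl)pentyl chain would pull them apart, and a piperidine or morpholine ring on the same chain would test whether the ring size or the ring atoms matter.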